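The source may hold more compounds than are shown below. What is called first, only, known or untested is meant among the compounds shown, and "the series" means these compounds.

Measured in an ADME assay on cells for inhibition of cytochrome P450 11B1, mitochondrial (Homo sapiens), read by HPLC, with a stated time of 60 min; on this read-out higher numbers stand for weaker inhibition and lower numbers for stronger inhibition:
compound 1 `Fc1ccc2nc(-n3ccnn3)n(C3CC3)c2c1` — 9070 nM
compound 2 `Fc1ccc2nc(-c3cnco3)n(C3CC3)c2c1` — a limit only, > 10000 nM
compound 3 `Fc1ccc2nc(-c3cncs3)n(C3CC3)c2c1` — 4520 nM

Compound 3 carries the lowest of the two numbers given here. Its nearest neighbour is compound 1, and a 2.0-fold lower number from compound 1 to compound 3 (0.30 log units; within the scatter). Compound 2 sits at the limit of > 10000 nM in this assay, at which 1 of the 3 values shown sits. From that limit, an at least 2.2-fold lower number from compound 2 to compound 3 (0.34 log units; beyond the scatter). Between the first two, an at least 1.1-fold higher number from compound 1 to compound 2 (0.04 log units; that floor lies within the scatter).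

Compound 4 `Fc1ccc2nc(-c3cccnn3)n(C3CC3)c2c1` is not yet measured in this assay. It differs from compound 3 in one place: pyridazin-3-yl in place of 1,3-thiazol-5-yl on an aromatic carbon.

Within the data shown here, the steps that bear on this change are the exchanges of a five-membered aromatic ring at the same aromatic carbon, namely a 2.0-fold lower number from compound 1 to compound 3 (0.30 log units; within the scatter) and an at least 2.2-fold lower number from compound 2 to compound 3 (0.34 log units; beyond the scatter). Among the measured compounds shown here, both stay at or just beyond the scatter, and every ring tried so far has been five-membered, so no measured step speaks directly to a six-membered pyridazin-3-yl. On this basis a step of no more than the scatter is expected in either direction, with some chance of a limit. For compound 4 the expected value is 6500 nM, in the range 2000 nM to 20000 nM. That estimate corresponds to an expected 1.4-fold higher number from compound 3 to compound 4 (0.16 log units; within the scatter).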

Compound 4, half-maximal inhibitory concentration: > 10000 nM
Compound 4: a limit, no number (the forecaster's own chance of this, stated with the estimate: 35%); middle value at least 1.5-fold (0.18 log units) from the limit.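

Replacing 1,3-thiazol-5-yl by pyridazin-3-yl on this aromatic carbon weakens inhibition in this assay, with an at least 2.2-fold higher number from compound 3 to compound 4 (0.34 log units; beyond the scatter) as the step, so this position does not accept every aromatic ring with two hetero atoms equally. Against the triazole of the core series the reading is less clear, with an at least 1.1-fold higher number from compound 1 to compound 4 (0.04 log units; that floor lies within the scatter) as the step, and the steps between the two limit compounds cannot be read. Compound 4 is a limit and not a number, and so is compound 2, which places a six-membered and a five-membered ring at the same limit: the limit of > 10000 nM in this assay, at which 2 of the 4 values shown sit.

Whether the loss belongs to six-membered rings in general or to pyridazin-3-yl alone stays open, as only one six-membered ring is shown. A pyridin-3-yl or pyrimidin-5-yl ring here would separate these two readings.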